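A few compounds are considered here, and "the series" means these few. Any claim that something is new, unique, unknown or untested is made for them only; others in the source may bear on it.

Measured so far in a functional assay on MCF7 cells (Homo sapiens) for antiproliferative activity, with a stated time of 5 days; on this read-out higher numbers stand for weaker inhibition and lower numbers for stronger inhibition:

- compound 1, `COc1ccc(-c2[nH]c3ccc(C(C)C)cc3c2C=O)cc1`: 97 nM
- compound 2, `COc1ccc(-c2[nH]c3ccc(C(C)(C)C)cc3c2C=O)cc1`: 580 nM
- compound 3, `CCCCc1ccc2[nH]c(-c3ccc(OC)cc3)c(/C=N\C)c2c1`: 27 nM

Compound 1 and compound 2 share one core. Compound 2 carries methyl in place of hydrogen on a saturated chain carbon bound to an aromatic carbon and two saturated chain carbons and the measured step is a 6.0-fold higher number from compound 1 to compound 2 (0.78 log units; beyond the scatter). Compound 3 sits on a different core; how the two cores differ is not broken down here. In this assay compound 3 gives the lowest number of the three, with both other compounds lying beyond the scatter from it.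

Compound 4, `CCCCCc1ccc2[nH]c(-c3ccc(OC)cc3)c(/C=N\C)c2c1`, is not yet measured. It differs from compound 3 by methyl in place of hydrogen on a saturated chain carbon, four bonds along the chain from an aromatic carbon. This is the same kind of change as that from compound 1 to compound 2, not the same change: there the carbon that takes the methyl is bound to an aromatic carbon and two saturated chain carbons, here it lies four bonds along the chain from an aromatic carbon. Among the compounds with values here, the only measured step of this kind is a 6.0-fold higher number from compound 1 to compound 2 (0.78 log units; beyond the scatter), taken at a different place and on a different core, so it gives only a loose guide. Because a 6.0-fold higher number from compound 1 to compound 2 (0.78 log units; beyond the scatter) was made at a branched position, the step from compound 3 to compound 4 is expected to be smaller, near a 1.7-fold higher number from compound 3 to compound 4 (0.22 log units; within the scatter). Compound 4 is expected to give 45 nM, with a likely range from 15 nM to 130 nM.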

Compound 4, half-maximal inhibitory concentration: 21 nM
Compound 4: the middle estimate sits 2.1-fold (0.33 log units) above what was measured; the measured number falls inside the stated range.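

In this assay the new step is a 1.3-fold lower number from compound 3 to compound 4 (0.11 log units; within the scatter), so on the core of compound 3 methyl in place of hydrogen at this place on the chain leaves the number unmoved within the scatter. The change does not carry a single step size from one core to the other in this series: the same change on two cores in this assay, a 6.0-fold higher number (0.78 log units; beyond the scatter) from compound 1 to compound 2 and a 1.3-fold lower number (0.11 log units; within the scatter) from compound 3 to compound 4, 7.7-fold (0.89 log units) apart, beyond the scatter of two such steps

What this does not show is whether the core itself sets the size of the step, since the methyl also sits at a different place in each pair: on a saturated chain carbon bound to an aromatic carbon and two saturated chain carbons in one, and four bonds along the chain from an aromatic carbon in the other.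

The compounds shown leave open what the same methyl does at one place on both cores, which would separate core from place. They also leave open whether a longer chain, or an amine at the chain end, on the core of compound 3 would keep the number within the scatter.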